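This account rests on a few compounds, and the source may have more. Where it says the series, first, only, none or still open, it means among the compounds named here.

Of the compounds shown here, three sharing one core have been measured in a functional assay on MGC-803 cells (Homo sapiens) for inhibition, read by CCK-8 assay, with a stated time of 48 h; a lower number here means a stronger inhibitor, a higher number a weaker inhibitor. Compound 1 `COc1ccc(CN(C(=O)CSc2nc3ccccc3o2)c2cc(OC)c(OC)c(OC)c2)cc1` gives 450 nM, compound 2 `COc1ccc(CN(C(=O)CSC(=S)N2CCN(C)CC2)c2cc(OC)c(OC)c(OC)c2)cc1` gives 1280 nM, and compound 3 `CCN1CCN(C(=S)SCC(=O)N(Cc2ccc(OC)cc2)c2cc(OC)c(OC)c(OC)c2)CC1` gives 9890 nM. Compound 3 thus stands at the highest number of the three: its nearest neighbour is compound 2, and the step of a 7.7-fold higher number from compound 2 to compound 3 (0.89 log units; beyond the scatter) is beyond the scatter, as is the larger step of a 22-fold higher number from compound 1 to compound 3 (1.34 log units; beyond the scatter) from compound 1.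

Compound 4 `COc1ccc(CN(C(=O)CSC(=S)N2CCN(Cc3ccc(C(C)(C)C)cc3)CC2)c2cc(OC)c(OC)c(OC)c2)cc1` is the next compound, and it differs from compound 3 in one place: 4-(tert-butyl)phenyl in place of methyl on a saturated chain carbon bound to an amine nitrogen in a ring. For the measured compounds named here, the only measured step that touches the same place is the one from compound 2 to compound 3, where methyl in place of hydrogen on a saturated chain carbon bound to an amine nitrogen in a ring gave a 7.7-fold higher number from compound 2 to compound 3 (0.89 log units; beyond the scatter). Going by the values given here, that step went in the direction of a weaker inhibitor, but the change from methyl to 4-(tert-butyl)phenyl is far larger than a single added carbon, and no measured pair shows what an aromatic group at this position does. The expectation for compound 4 is therefore wide: the number in this assay is estimated to move by a 2.8-fold lower number from compound 3 to compound 4 (0.45 log units; beyond the scatter). Compound 4 is expected to give about 3500 nM, within a range from 600 nM to 15000 nM.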

Compound 4, half-maximal inhibitory concentration: 5390 nM
Compound 4: middle estimate off by 1.5-fold (0.19 log units), on the low side, within the range that was stated.
By their numbers in this assay, from the lowest: compound 1; then compound 2; then compounds 4 and 3 (each within the scatter of the next).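

Replacing methyl with the much larger 4-(tert-butyl)phenyl on the saturated chain carbon bound to an amine nitrogen in a ring gives a 1.8-fold lower number from compound 3 to compound 4 (0.26 log units; within the scatter) in this assay, so this position accommodates a large aromatic group without a change beyond the scatter. The earlier compounds showed only the small addition to compound 2, a 7.7-fold higher number from compound 2 to compound 3 (0.89 log units; beyond the scatter), and the new comparison with the same parent, a 4.2-fold higher number from compound 2 to compound 4 (0.62 log units; beyond the scatter), shows that 4-(tert-butyl)phenyl also leaves the number higher than hydrogen does at this place, so among these three compounds, both compound 3 and compound 4 are weaker inhibitors than compound 2, and none goes against this. No supporting evidence bears on why this position responds in this way.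

The compounds shown leave open whether the tert-butyl group matters at all, since an unsubstituted phenyl at this place would be needed to separate its contribution from that of the aromatic ring. They also leave open how a carboxylic acid, a primary amine or a longer chain at the same place would compare with hydrogen in this assay.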